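Removing the methoxy from compound 2: expected cytotoxicity

The source may report more compounds than this note shows. Statements on the series, on what has been measured and on what is new or still open speak of the compounds shown alone.

Two compounds of this series carry numbers in an ADME assay on L1210/0 cells (Mus musculus) for cytotoxicity, with a stated time of 48 h; on this read-out higher numbers stand for weaker inhibition and lower numbers for stronger inhibition. Compound 1 `OC[C@@H]1CCC[C@@H]1Cn1cnc2c(Cl)ncnc21` gives 52500 nM in this assay. Compound 2 `COc1ccc(-c2ncnc3c2ncn3C[C@@H]2C[C@H](CO)c3ccccc32)cc1` gives 17600 nM in this assay, the lower of the two numbers; its nearest neighbour is compound 1, whose number lies higher by a margin beyond the usual scatter. For the measured compounds named here, compound 1 and compound 2 differ in more than one place, so their two values show only that compound 2 is the stronger inhibitor of the pair.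

Compound 3 `OC[C@H]1C[C@@H](Cn2cnc3c(-c4ccccc4)ncnc32)c2ccccc21` has not yet been measured in this assay. Relative to compound 2 the change is hydrogen in place of methoxy on an aromatic carbon: the methoxy leaves and hydrogen enters on an aromatic carbon of a six-membered aromatic ring of carbon only. Going by the values given here, no step between measured compounds shows the effect of this change, so the expectation rests on the value of compound 2 alone. Compound 3 is expected to give about 22000 nM in this assay, with a range from 8000 nM to 60000 nM. The step this estimate implies, a 1.3-fold higher number from compound 2 to compound 3 (0.10 log units; within the scatter), is expected to stay within the scatter, with no clear direction.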

Compound 3, half-maximal inhibitory concentration: 28100 nM
Compound 3: the middle estimate sits 1.3-fold (0.11 log units) below what was measured; measured number inside the range.
By their numbers in this assay, from the lowest: compounds 2, 3 and 1 (each within the scatter of the next, the first and the last beyond it).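

In this assay, for the compounds shown here, going from 4-methoxyphenyl to phenyl gives a 1.6-fold higher number from compound 2 to compound 3 (0.20 log units; within the scatter), the first step that isolates a single change. At this position, on an aromatic carbon para to a large group, methoxy and hydrogen cannot be told apart by this read-out, and compound 3 cannot be ranked against compound 2, so the methoxy is not shown to contribute to the cytotoxicity measured here. No measured information is available to explain this outcome.

On these data alone, what a group other than methoxy or hydrogen would do at this same place remains open: an amine, a carboxylic acid or a longer chain such as butoxy could still move the number beyond the scatter, and a single pair of compounds gives no direction for any of them. Compound 1 differs from compound 2 and from compound 3 in more than one place, so its number cannot be tied to any one structural change, and the contribution of the aryl group, the chlorine and the rest of the scaffold remains unresolved.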